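Two Inactive Sulfonamides and a Dichlorophenyl Variant

A few compounds are considered here, and "the series" means these few. Any claim that something is new, unique, unknown or untested is made for them only; others in the source may bear on it.

Measured so far:
compound 1 `CCc1ccc(S(=O)(=O)Nc2ccc(-c3nc4ccccc4o3)cc2)cc1`: > 63000 nM
compound 2 `O=S(=O)(Nc1ccc2oc(-c3ccccc3)nc2c1)c1ccc(F)c(C(F)(F)F)c1`: > 63000 nM

In an assay on isolated protein for inhibition of malate dehydrogenase, mitochondrial (Sus scrofa), with stated times of 45 min and 30 min (a lower number here means a stronger inhibitor, a higher number a weaker inhibitor), compound 1 gives only a limit of the assay, > 63000 nM. Compound 2 likewise reaches only a limit in this assay, > 63000 nM. Both measured values therefore sit at the limit of > 63000 nM in this assay, at which 2 of the 2 values shown sit, and compound 1 cannot be placed higher or lower than compound 2 on the numbers shown; neither gives a true number.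

Compound 3 `O=S(=O)(Nc1ccc(-c2nc3ccccc3o2)cc1)c1ccc(Cl)c(Cl)c1` differs from compound 1 at a single place: 3,4-dichlorophenyl in place of 4-ethylphenyl on a sulfonyl sulfur. Within the data shown here, no step between measured compounds is available to calibrate this change, and nothing in the two measured values points either way. The expectation is that the step from compound 1 to compound 3 in this assay is none beyond the scatter, with a step that the limit leaves unreadable from compound 1 to compound 3. Compound 3 is accordingly estimated at 70000 nM, in a range from 20000 nM to 250000 nM, most likely again returned only as a limit.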

Compound 3, half-maximal inhibitory concentration: > 63000 nM
Compound 3: a limit, no number; the forecaster's own chance of this, stated with the estimate: 80%; the middle value lies beyond the limit too.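

Compound 3 also returns only a limit in this assay, > 63000 nM. Among these compounds, no step from compound 1 to compound 3 can therefore be read, since every value shown is a limit: the limit of > 63000 nM in this assay, at which 3 of the 3 values shown sit. The compounds shown leave open what change, if any, would give a true number in this assay.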